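This account rests on a few compounds, and the source may have more. Where it says the series, first, only, none or still open, it means among the compounds named here.

Among the two measured compounds, compound 2 (`COc1ncc(-c2ccc3nc(NC(=O)NCCN(C)C)nn3c2)cc1NS(=O)(=O)c1ccc(F)cc1`) stands lowest in a functional assay on A549 cells (Homo sapiens) for cytotoxicity, read by MTT assay, with a stated time of 72 h (a higher number here means a weaker inhibitor, a lower number a stronger inhibitor), with 800 nM against compound 1 (`COc1ncc(-c2ccc3nc(NC(=O)NCC(=O)N4CCCC4)nn3c2)cc1NS(=O)(=O)c1ccc(F)cc1`) with 2190 nM on the same scale. Compound 3 (`CCCNC(=O)Nc1nc2ccc(-c3cnc(OC)c(NS(=O)(=O)c4ccc(F)cc4)c3)cn2n1`) keeps the shared core and the urea chain of compound 2 but ends that chain differently: methyl in place of dimethylamino on a saturated chain carbon, two bonds along the chain from an amide-type nitrogen. For the measured compounds named here, only one measured step bears on this change. That step, a 2.7-fold lower number from compound 1 to compound 2 (0.44 log units; beyond the scatter) in this assay, altered the same chain and was modest. It does not settle the present case, since neither measured compound ends in a plain propyl chain. Compound 2 holds the lower number of the pair, and losing its dimethylamino group is therefore expected to move the number upward by a modest amount of similar size. The expected change is a 2.3-fold higher number from compound 2 to compound 3 (0.35 log units; beyond the scatter) in this estimate. Compound 3 is estimated at 1800 nM with an expected range from 600 nM to 5000 nM in this assay before any measurement.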

Compound 3, half-maximal inhibitory concentration: 220 nM
Compound 3: the middle estimate sits 8.2-fold (0.91 log units) above what was measured; the measured number lies below the stated range.
By their numbers in this assay, from the lowest: compound 3; then compound 2; then compound 1.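

In this assay, taking away the dimethylamino group and ending the urea chain in methyl, on a saturated chain carbon two bonds along the chain from an amide-type nitrogen, gave a 3.6-fold lower number from compound 2 to compound 3 (0.56 log units; beyond the scatter) rather than a rise. The earlier pair showed only that one chain end bearing nitrogen gave a lower number than another, which left open whether this position needs a nitrogen at all; the propyl chain of compound 3 shows that the lowest number of the three needs neither the dimethylamino group nor any other nitrogen beyond the urea. Across the full change of chain end, the ethyl-for-(pyrrolidin-1-yl)carbonyl replacement gives a 10-fold lower number from compound 1 to compound 3 (1.00 log units; beyond the scatter) in this assay, and no measurement offered here accounts for the direction of either step.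

The compounds shown leave open whether the number keeps falling with a butyl or longer chain, or rises again once the chain grows. They also leave open how a hydroxyl group, a primary amine or a carboxylic acid at the end of the propyl chain would compare with the plain methyl end.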